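Chloro for methyl in the maximal electroshock series

A few compounds are considered here, and "the series" means these few. Any claim that something is new, unique, unknown or untested is made for them only; others in the source may bear on it.

In a functional assay on the whole organism for antagonist activity, with Mus musculus as the target, in the maximal electroshock model (on this read-out higher numbers stand for an effect only at larger amounts of compound and lower numbers for an effect already at smaller amounts), compound 1 `COC(=O)NC1=NC(c2ccccc2C)CN1` gives 55 mg/kg and compound 2 `COC(=O)NC1=NC(c2cccc(C)c2)CN1` gives 100 mg/kg while compound 3 `COC(=O)NC1=NC(c2cccc(F)c2)CN1` gives 70 mg/kg with all three inside the usual scatter of one another, so compound 1 is not separated from the other two. Compound 4 `COC(=O)NC1=NC(c2ccccc2Cl)CN1` differs from compound 1 by chloro in place of methyl on an aromatic carbon and carries chloro in place of methyl on an aromatic carbon, ortho to a large group. Within the data shown here, the one measured swap of this kind, fluoro in place of methyl on an aromatic carbon, is a 1.4-fold lower number from compound 2 to compound 3 (0.15 log units; within the scatter) and lies within the scatter. Among the measured compounds shown here, no chloro compound has been measured, so this is only a loose guide. No change beyond the scatter is expected, and the estimated 1.1-fold higher number from compound 1 to compound 4 (0.04 log units; within the scatter) remains small. The estimate for compound 4 is 60 mg/kg with 30 mg/kg to 115 mg/kg as its expected range.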

Compound 4, dose for half-maximal effect: 50 mg/kg
The estimate for compound 4 lay 1.2-fold (0.08 log units) above the measured number; measured number inside the range.
By their numbers in this assay, from the lowest: compounds 4, 1, 3 and 2 (each within the scatter of the next).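

Working notes: at this place, ortho to a large group, chloro in place of methyl on an aromatic carbon gives a 1.1-fold lower number from compound 1 to compound 4 (0.04 log units; within the scatter) in this assay. Among these compounds, this is the first single swap read at this position and the first with chloro; the earlier swap, a 1.4-fold lower number from compound 2 to compound 3 (0.15 log units; within the scatter), sat elsewhere on the ring and involved fluoro. Methyl and chloro are therefore not separated here, and nothing measured accounts for that.

On these data alone, whether an amine or a carboxylic acid on this aromatic carbon would move the number beyond the scatter remains open. So does the effect of a change to the methyl carbamate part of the shared core.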